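Shortening the Chain Further: From Compound 3 to Compound 4

A few compounds are considered here, and "the series" means these few. Any claim that something is new, unique, unknown or untested is made for them only; others in the source may bear on it.

Three compounds sharing one core differ only in the length of a saturated chain. Compound 1 `CCCCCCCCCCCCCCc1cc(NC(=O)Nc2c(C(C)C)cccc2C(C)C)on1` gives 28 nM in an assay on microsomes from intestine for inhibition of acyl-CoA:cholesterol acyltransferase (Oryctolagus cuniculus); on this read-out higher numbers stand for weaker inhibition and lower numbers for stronger inhibition. Compound 2 `CCCCCCCCCCCCCc1cc(NC(=O)Nc2c(C(C)C)cccc2C(C)C)on1` gives 13 nM in this assay, and compound 3 `CCCCCCCCCCCCc1cc(NC(=O)Nc2c(C(C)C)cccc2C(C)C)on1` gives 19 nM in this assay, standing second highest of the three and within the scatter of both others. Compound 4 `CCCCCCCCCCc1cc(NC(=O)Nc2c(C(C)C)cccc2C(C)C)on1` carries one further change: hydrogen in place of ethyl on a saturated chain carbon, ten or more bonds along the chain from an aromatic carbon. The same loss of an ethyl appeared once before as a 1.5-fold lower number from compound 1 to compound 3 (0.17 log units; within the scatter), which stayed within the scatter, while the single-carbon steps a 2.2-fold lower number from compound 1 to compound 2 (0.33 log units; beyond the scatter) and a 1.5-fold higher number from compound 2 to compound 3 (0.16 log units; within the scatter) disagree in direction. The step of a 1.3-fold higher number from compound 3 to compound 4 (0.12 log units; within the scatter) is therefore expected to stay within the scatter. Compound 4 is expected at 25 nM, with a range from 9 nM to 70 nM.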

Compound 4, half-maximal inhibitory concentration: 29 nM
Estimate against measurement, compound 4: 1.2-fold (0.06 log units) below; the measured number falls inside the stated range.
By their numbers in this assay, from the lowest: compounds 2, 3, 1 and 4 (each within the scatter of the next, the first and the last beyond it).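

Losing an ethyl at this place again stays within the scatter (a 1.5-fold higher number from compound 3 to compound 4 (0.18 log units; within the scatter)), but shortening the chain further can now be seen to matter: the change of hydrogen for propyl lies beyond the scatter (a 2.2-fold higher number from compound 2 to compound 4 (0.35 log units; beyond the scatter)). Chain length still gives no steady trend, since compound 1 goes against one, with hydrogen for butyl staying within the scatter (a 1.0-fold higher number from compound 1 to compound 4 (0.02 log units; within the scatter)). Nothing available explains these differences.

From the compounds shown here alone, whether a much shorter chain such as butyl, or a chain ending in a carboxylic acid or an amine, would keep this inhibition remains open.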